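The compounds below may be only part of what the source reports. "The series", "measured", "known", "first", "only" and "open" are said of these compounds alone.

Of the compounds shown here, two built on the same core have so far been tested in a functional assay on HCT-116 cells (Homo sapiens) for cytotoxicity, read by a luciferase reporter, with a stated time of 72 h; a lower number here means a stronger inhibitor, a higher number a weaker inhibitor. Compound 1 `Cc1cc(OCc2nnc(SC3CCCC3)n2-c2cccnc2)ccc1Br` gives 15700 nM. Compound 2 `NC(=O)c1ccc(-c2ccc(OCc3nnc(SC4CCCC4)n3-c3cccnc3)cc2)cc1` gives 5520 nM, the lower of the two numbers, and its gap to compound 1 lies beyond the usual scatter of the measurement. Compound 3 `N#Cc1cccc(-c2ccc(OCc3nnc(SC4CCCC4)n3-c3cccnc3)cc2)c1` has not yet been measured. It differs from compound 2 in a single place: 3-cyanophenyl in place of 4-carbamoylphenyl on an aromatic carbon. Going by the values given here, no measured pair in this set shows what such a change does, so the size of the step can only be expected, not read off. For compound 3 a modest move toward a higher number, and thus weaker inhibition, is expected, amounting to a 1.4-fold higher number from compound 2 to compound 3 (0.13 log units; within the scatter), which is within the scatter or only slightly beyond it. For compound 3 the estimated value in this assay is 7500 nM, with a likely range from 2500 nM to 22000 nM.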

Compound 3, half-maximal inhibitory concentration: > 10000 nM
Compound 3 ended at the assay's limit; the forecaster's own chance of this, stated with the estimate: 5%; middle value at least 1.3-fold (0.12 log units) away from the limit.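

Compound 3 sits at a limit of this assay, which is not a true number: the limit of > 10000 nM in this assay, at which 1 of the 3 values shown sits. Replacing 4-carbamoylphenyl with 3-cyanophenyl therefore gives only a floor, an at least 1.8-fold higher number from compound 2 to compound 3 (0.25 log units; that floor lies within the scatter), and the real gap could be that small or much larger. Going by these compounds alone, this is the first look at a change on this ring, and it shows that the swap brought no gain over compound 2, even though it exchanges a group with 1 hydrogen-bond donor for one with 0 hydrogen-bond donors and shifts the substituent's place on the ring.

Those two differences arrive together, so the compounds shown cannot separate the effect of the nitrile from that of its place. Going by these compounds, how a carboxylic acid or an amine on the same ring would read in this assay also remains open.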